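Notes on compound 4: fluoro in place of tert-butyl

A few compounds are considered here, and "the series" means these few. Any claim that something is new, unique, unknown or untested is made for them only; others in the source may bear on it.

Compound 1 `C[C@@H](NC(=O)Nc1ccc(C(C)(C)C)cc1)c1ccccc1` stands lowest of the three numbers in an ADME assay on the whole organism with Oryza sativa as the target, tested at 10 uM (on this read-out lower numbers stand for a stronger effect and higher numbers for a weaker effect at the one concentration tested), where compound 1 gives 53%. Its configurational partner compound 2 `C[C@H](NC(=O)Nc1ccc(C(C)(C)C)cc1)c1ccccc1` gives 64%, and the step of a number 11 percentage points higher from compound 1 to compound 2 (beyond the scatter) rests on the fact that compounds 1 and 2 differ only in the configuration as drawn alone. Compound 3 `CC(=O)c1ccccc1NC(=O)N[C@H](C)c1ccccc1` gives 89%, the highest of the three. Compound 4 `C[C@@H](NC(=O)Nc1ccc(F)cc1)c1ccccc1` differs from compound 1 by fluoro in place of tert-butyl on an aromatic carbon. Among the measured compounds shown here, no measured step bears on this change: the single measured step concerns configuration only, and compound 3 differs from compound 1 in more than one place. The expected step is a number 12 percentage points higher from compound 1 to compound 4 (beyond the scatter), a guess without support from any measured pair. Compound 4 is estimated at 65%, within 45% to 85%.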

Compound 4, a percentage reported as activity, at one concentration (the size of the read-out at that concentration, not a potency): 92%
Compound 4: middle estimate off by 27 percentage points, on the low side, and the stated range ends below it.
By their numbers in this assay, from the lowest: compound 1; then compound 2; then compounds 3 and 4 (each within the scatter of the next).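

In this assay, fluoro in place of tert-butyl on an aromatic carbon gives a number 39 percentage points higher from compound 1 to compound 4 (beyond the scatter), so the read-out responds strongly to the group at this position. Among the compounds shown here, the only earlier step, a number 11 percentage points higher from compound 1 to compound 2 (beyond the scatter), is a smaller step and concerns configuration alone. The evidence at hand concerns configuration and does not bear on this change.

Going by these compounds, how a methoxy, an isopropyl or a carboxylic acid on that aromatic carbon would read remains open. Also open, on these data alone, is whether the same exchange gives a similar step in the configuration of compound 2.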